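Trifluoromethyl for Fluoro: Estimating Cell Growth Inhibition

A few compounds are considered here, and "the series" means these few. Any claim that something is new, unique, unknown or untested is made for them only; others in the source may bear on it.

Measured compounds in a functional assay on A549 cells (Homo sapiens) for inhibition, read by MTT assay, with a stated time of 72 h, tested at 10 uM; on this read-out lower numbers stand for less inhibition and higher numbers for more inhibition at the one concentration tested (going by the name of the read-out):
compound 1, `CCOC(=O)C1=C(Nc2ccccc2)S/C(=C\c2ccc[nH]2)C1=O`, gives 23.5%.
compound 2, `CCOC(=O)C1=C(Nc2cccc(F)c2)S/C(=C\c2ccc[nH]2)C1=O`, gives the limit < 10%, a limit of the assay and not a number.

Compound 2 therefore stands at the bottom of what is shown: its reading in this assay is only a limit, as the limit of < 10% in this assay, at which 1 of the 2 values shown sits, makes plain. Among the measured compounds shown here, the single measured step, a number at least 13.5 percentage points lower from compound 1 to compound 2 (beyond the scatter), shows that putting fluoro onto that aromatic carbon took the inhibition from a modest number down to the limit.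

Compound 3, `CCOC(=O)C1=C(Nc2cccc(C(F)(F)F)c2)S/C(=C\c2ccc[nH]2)C1=O`, differs from compound 2 by trifluoromethyl in place of fluoro on an aromatic carbon. For the measured compounds named here, no measured step covers trifluoromethyl in place of fluoro, so the expectation rests on the fact that a substituent on that carbon already sits at the limit, seen in a number at least 13.5 percentage points lower from compound 1 to compound 2 (beyond the scatter). Swapping one such substituent for another is expected to leave the inhibition low, with the change a number no lower from compound 2 to compound 3 (the limit leaves the size open) taken as within scatter. For compound 3 the expected value in this assay is 10%, with a range from 0% to 28%.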

Compound 3, a percentage reported as inhibition, at one concentration (the size of the read-out at that concentration, not a potency): 22.8%
The estimate for compound 3 lay 12.8 percentage points below the measured number; measured number inside the range.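

In this assay, trifluoromethyl in place of fluoro on this aromatic carbon gives a number at least 12.8 percentage points higher from compound 2 to compound 3 (beyond the scatter) and so brings the reading back up from the limit, which shows that a substituent at this place does not by itself abolish the inhibition. Trifluoromethyl in place of hydrogen on the same carbon gives a number 0.7 percentage points lower from compound 1 to compound 3 (within the scatter) and so leaves the reading much as it stood in the unsubstituted parent, with fluoro in compound 2 the only one of the three compounds that goes against this. On these data alone, the full size of the rise on swapping fluoro for trifluoromethyl stays unknown because the reading for compound 2 is a limit of the assay and not a number: the limit of < 10% in this assay, at which 1 of the 3 values shown sits.

As far as these compounds go, the three compounds compare only hydrogen, fluoro and trifluoromethyl at this one place, so it remains open whether an amine, a carboxylic acid or a methoxy group there would read like compound 2 or like compound 3. From the compounds shown here alone, it is also open whether the same swap elsewhere on the aromatic ring, or at concentrations other than the single one tested here, would tell the same story.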